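From 4-aminophenyl to 1H-indol-6-yl on a shared core

The compounds below may be only part of what the source reports. "The series", "measured", "known", "first", "only" and "open" are said of these compounds alone.

In a functional assay on NCI-H460 cells (Homo sapiens) for antiproliferative activity, read by MTT assay, with a stated time of 48 h (on this read-out higher numbers stand for weaker inhibition and lower numbers for stronger inhibition), compound 1 `COc1cc(-c2cccc3nc(-c4ccc(F)cc4)oc23)cc(OC)c1OC` gives 8700 nM. Compound 2 `COc1cc(-c2cccc3nc(-c4cccc(C)c4)oc23)cc(OC)c1OC` is reported only as a limit of the assay, > 25000 nM. Compound 3 `COc1cc(-c2cccc3nc(-c4ccc(N)cc4)oc23)cc(OC)c1OC` gives 310 nM, the lower of the two exact numbers and so the strongest inhibition seen here.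

Compound 4 `COc1cc(-c2cccc3nc(-c4ccc5cc[nH]c5c4)oc23)cc(OC)c1OC` has not yet been measured. It carries 1H-indol-6-yl in place of 4-aminophenyl on an aromatic carbon. Among the compounds with values here, two measured steps bear on this place, and both lead to the group that now leaves. Amino in place of fluoro gave a large step, a 28-fold lower number from compound 1 to compound 3 (1.45 log units; beyond the scatter). 4-Aminophenyl in place of 3-methylphenyl also gave a large step, an at least 80-fold lower number from compound 2 to compound 3 (1.90 log units; beyond the scatter). Compound 4 still has a hydrogen-bond donor, but it loses the amino group that marks the step of a 28-fold lower number from compound 1 to compound 3 (1.45 log units; beyond the scatter), so part of that gain may be lost. A moderate move towards weaker inhibition is therefore expected, a 2.9-fold higher number from compound 3 to compound 4 (0.46 log units; beyond the scatter). In this assay, the estimate for compound 4 is 900 nM, within a range of 120 nM to 7000 nM.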

Compound 4, half-maximal inhibitory concentration: 24 nM
Estimate against measurement, compound 4: 38-fold (1.57 log units) above; the measured number lies below the stated range.
By their numbers in this assay, from the lowest: compound 4; then compound 3; then compound 1. At a limit, above all of these: compound 2.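

The amino group of compound 3 is not required for strong inhibition at this place: in this assay, 1H-indol-6-yl goes further, with a 13-fold lower number from compound 3 to compound 4 (1.11 log units; beyond the scatter). The earlier contrast between aryl groups also widens, with a 360-fold lower number from compound 1 to compound 4 (2.56 log units; beyond the scatter). Compound 2 is held only as a limit of the assay, so its step, an at least 1000-fold lower number from compound 2 to compound 4 (3.01 log units; beyond the scatter), is a bound and not an exact size: the limit of > 25000 nM in this assay, at which 1 of the 4 values shown sits.

The compounds shown do not tell whether the gain comes from the added five-membered ring or from the hydrogen-bond donor it carries, as both 4-aminophenyl and 1H-indol-6-yl have a donor. A benzofuranyl group, or an indolyl group with a methyl on its ring nitrogen, at the same place would separate the two.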